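This account rests on a few compounds, and the source may have more. Where it says the series, first, only, none or still open, it means among the compounds named here.

Measured so far in a functional assay on MCF7 cells (Homo sapiens) for antiproliferative activity, read by MTT assay, with a stated time of 72 h; a lower number here means a stronger inhibitor, a higher number a weaker inhibitor: compound 1 `COc1cccc(-c2ccc3ncn(-c4cc(OC)c(OC)c(OC)c4)c3c2)c1` with 1610 nM; compound 2 `COc1ccc(-c2ccc3ncn(-c4cc(OC)c(OC)c(OC)c4)c3c2)cc1` with 210 nM; compound 3 `COc1cc(-n2cnc3ccc(-c4ccccc4)cc32)cc(OC)c1OC` with 2290 nM.

Compound 3 gives the highest of the three numbers; its gap to compound 1 is within the scatter, whereas an 11-fold higher number from compound 2 to compound 3 (1.04 log units; beyond the scatter) lies beyond it. Compound 4 `COc1cc(-n2cnc3ccc(-c4ccc(F)cc4)cc32)cc(OC)c1OC` carries fluoro in place of hydrogen on an aromatic carbon. Among the compounds with values here, no measured step exchanges hydrogen for fluoro. The steps that bear are the methoxy removals, a 1.4-fold higher number from compound 1 to compound 3 (0.15 log units; within the scatter) and an 11-fold higher number from compound 2 to compound 3 (1.04 log units; beyond the scatter), together with a 7.7-fold lower number from compound 1 to compound 2 (0.88 log units; beyond the scatter): a substituent on that terminal ring can shift the number strongly, though how far depends on the substituent. Fluoro is a different group from methoxy, so a smaller gain is expected. Compound 4 is estimated at 1200 nM, with a range of 400 nM to 3500 nM. The expected step is a 1.9-fold lower number from compound 3 to compound 4 (0.28 log units; within the scatter), toward a lower number.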

Compound 4, half-maximal inhibitory concentration: 1770 nM
Beside the measured number, compound 4's estimate is 1.5-fold (0.17 log units) below it; measured number inside the range.
By their numbers in this assay, from the lowest: compound 2; then compounds 1, 4 and 3 (each within the scatter of the next).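

In this assay the change from phenyl to 4-fluorophenyl gives a 1.3-fold lower number from compound 3 to compound 4 (0.11 log units; within the scatter) and so does not separate the two compounds. The strong shift seen with 4-methoxyphenyl does not extend to fluoro at this place, with an 8.4-fold higher number from compound 2 to compound 4 (0.93 log units; beyond the scatter) while a 1.1-fold higher number from compound 1 to compound 4 (0.04 log units; within the scatter) leaves 4-fluorophenyl and 3-methoxyphenyl inseparable. Nothing available explains why fluoro and methoxy differ here.

Open, going by these compounds, is whether the shift is particular to methoxy or also appears with a hydroxyl, an amine or a longer ether chain such as ethoxy at this place. Also open, on these data alone, is whether chloro or a carboxylic acid there would behave like fluoro.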